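An Ethoxy Group on the Phenyl Ring of Compound 1

A few compounds are considered here, and "the series" means these few. Any claim that something is new, unique, unknown or untested is made for them only; others in the source may bear on it.

Compound 1 `CCCCC[C@H](CN(O)C=O)C(=O)NCNC(=O)c1ccc(-c2ccccc2)o1` is one of two measured compounds here. In an assay on CHO cells for inhibition of bone morphogenetic protein 1 (Homo sapiens), with stated times of 10 min and 60 min (on this read-out higher numbers stand for weaker inhibition and lower numbers for stronger inhibition), compound 1 gives 25 nM. Among the compounds with values here, the other measured compound, compound 2 `CCCCC[C@@H](C(=O)NCNC(=O)c1cc2cccc(OC)c2o1)[C@@H](CC)N(O)C=O`, differs from it in several places at once and gives 126 nM in this assay; that number is higher than the one for compound 1 by more than the usual scatter, so compound 1 stands as the stronger inhibitor of the two. Compound 3 `CCCCC[C@H](CN(O)C=O)C(=O)NCNC(=O)c1ccc(-c2cccc(OCC)c2)o1` has not been measured. Relative to compound 1 it carries ethoxy in place of hydrogen on an aromatic carbon. Within the data shown here, no pair of measured compounds differs by this change alone, so the data give no direct guide to its size. The expectation is a step of a 1.3-fold lower number from compound 1 to compound 3 (0.10 log units; within the scatter) that stays within the scatter, with at most a slight lean toward stronger inhibition. Compound 3 is estimated at 20 nM in this assay, with a likely range from 6 nM to 70 nM.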

Compound 3, half-maximal inhibitory concentration: 1 nM
Compound 3: middle estimate off by 20-fold (1.30 log units), on the high side, and the stated range ends above it.
By their numbers in this assay, from the lowest: compound 3; then compound 1; then compound 2.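

Placing an ethoxy group on the phenyl ring of compound 1, meta to a large group, has a large effect in this assay and gives a 25-fold lower number from compound 1 to compound 3 (1.40 log units; beyond the scatter). The earlier compounds shown here could not show this, as they differed in several places at once and so revealed nothing about this position alone. The step shows that this position responds strongly to an added group of just 3 heavy atoms, although no measurement here accounts for the size of the step.

The compounds shown leave open whether a propyl chain, which carries no oxygen, or an amine at this same place would give a comparable step. They also leave open whether an ethoxy group elsewhere on the phenyl ring would do the same.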